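Cytotoxicity notes on compounds 1 to 4

The source may hold more compounds than are shown below. What is called first, only, known or untested is meant among the compounds shown, and "the series" means these compounds.

Measured so far in an ADME assay on HepG2 cells (Homo sapiens) for cytotoxicity, with a stated time of 72 h; on this read-out higher numbers stand for an effect only at larger amounts of compound and lower numbers for an effect already at smaller amounts:
- compound 1 `CSc1ccc(NC(=O)Nc2cc(C)nc3ccccc23)cc1` gives 16000 nM
- compound 2 `CSc1ccccc1NC(=O)Nc1cc(C)nc2ccccc12` reaches only a limit of the assay, > 25000 nM
- compound 3 `Cc1cc(NC(=O)Nc2cccc3nsnc23)c2ccccc2n1` also stops at a limit of the assay, > 25000 nM

In this assay, going by the values given here, compound 1 holds the only actual number among the three results; the other two are limits, not numbers. Two of the three results therefore sit at the limit of > 25000 nM in this assay, at which 2 of the 3 values shown sit, which leaves little to compare against. No pair of measured compounds differs in a single place, so no measured step is available and nothing among these three can be read as a trend.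

Compound 4 `COc1ccc(NC(=O)Nc2cc(C)nc3ccccc23)cc1` is not yet measured. Compared with compound 1 the change is methoxy in place of methylsulfanyl on an aromatic carbon. Among the compounds with values here, no measured step bears on this change, so the expectation rests on the small size of the exchange alone: the step from compound 1 to compound 4 is expected to stay within the scatter or to move somewhat toward higher concentrations, a 1.4-fold higher number from compound 1 to compound 4 (0.14 log units; within the scatter). Compound 4 is estimated at 22000 nM, with an expected range from 10000 nM to 50000 nM, and a fair chance that the assay reports only a limit.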

Compound 4, half-maximal effective concentration: > 25000 nM
Compound 4: a limit, no number; the forecaster's own chance of this, stated with the estimate: 40%; middle value at least 1.1-fold (0.05 log units) away from the limit.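

In this assay, going by these compounds alone, the exchange of methylsulfanyl for methoxy on an aromatic carbon, para to a large group, gives the series its first step between two compounds that differ in one place: an at least 1.5-fold higher number from compound 1 to compound 4 (0.19 log units; that floor lies within the scatter), and this is the only reading available for this position. Compound 4 gives > 25000 nM, which is a limit of the assay and not a number, so the step is known only by its floor and its full size cannot be read. With this result compound 1 remains the only compound shown with an actual number, and further changes at this position have little room to show up as numbers: the limit of > 25000 nM in this assay, at which 3 of the 4 values shown sit.

Going by these compounds, whether an amine, a carboxylic acid or a longer alkoxy chain in this place would bring the read-out back to a number remains open. Also open, on these data alone, is how far compound 4 lies from compound 1, and whether the exchange has any effect that exceeds the usual scatter.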